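The compounds below may be only part of what the source reports. "The series", "measured", "known", "first", "only" and "open" are said of these compounds alone.

In a functional assay on U-251 cells (Homo sapiens) (on this read-out higher numbers stand for weaker inhibition of growth and lower numbers for stronger inhibition of growth), two compounds built on the shared core have been measured so far. Compound 1 (`Cc1cc(C)c2c(O)cc(-c3ccc(Cl)cc3)nc2n1`) gives 30200 nM as the lower of the two numbers, and compound 2 (`COc1ccc(-c2cc(O)c3c(C)cc(C)nc3n2)cc1`) gives 91200 nM in the same test. Compound 1 is therefore the stronger growth inhibitor of this pair, although both numbers are large.

The next compound is compound 3 (`Cc1ccnc2nc(-c3ccc(Cl)cc3)cc(O)c12`), whose structure differs from that of compound 1 by hydrogen in place of methyl on an aromatic carbon in a single place. In words, this is hydrogen in place of methyl on an aromatic carbon, next to the ring nitrogen.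

Within the data shown here, the only measured step is a 3.0-fold higher number from compound 1 to compound 2 (0.48 log units; beyond the scatter) and it comes from methoxy in place of chloro on an aromatic carbon. That change is of a different kind and at a different place, so it gives a sense of scale but no direction. Among the measured compounds shown here, with no measured step that removes a methyl, a small change in this assay is the cautious expectation, perhaps none beyond the scatter.

The expected change is a 1.3-fold higher number from compound 1 to compound 3 (0.10 log units; within the scatter) as an estimate only. For compound 3 the estimated value is 38000 nM with an expected range from 14000 nM to 100000 nM in this test.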

Compound 3, concentration for 50% growth inhibition: 4570 nM
For compound 3 the middle estimate is 8.3-fold (0.92 log units) above the measured one; measured number below the stated range.
By their numbers in this assay, from the lowest: compound 3; then compound 1; then compound 2.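

In this assay, replacing the methyl next to the ring nitrogen with hydrogen gives a 6.6-fold lower number from compound 1 to compound 3 (0.82 log units; beyond the scatter), which means stronger inhibition of growth. This shows that the position next to the ring nitrogen matters to this read-out, and that the methyl there is not needed for the activity seen with compound 1; in this one pair, removing it helps. The earlier step, a 3.0-fold higher number from compound 1 to compound 2 (0.48 log units; beyond the scatter), concerned a different place and ran towards a higher number, so the two steps together show that the number can move in either direction with changes at two separate places on the shared core, while nothing measured here explains why this one falls.

As far as these compounds go, with only methyl and hydrogen compared at this position, it remains open whether a longer chain such as ethyl, an amine or a fluorine atom there would lower the number further or raise it again. From the compounds shown here alone, it is also open whether hydrogen at this position would bring a similar change when the chloro group is replaced by methoxy, and what the remaining methyl group contributes.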